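Methyl on the Oxetane Ring: Compound 2 to Compound 3

The source may report more compounds than this note shows. Statements on the series, on what has been measured and on what is new or still open speak of the compounds shown alone.

Compound 1 `CC(Sc1nc2nn(CC3COC3)cc2c(=O)n1-c1ccccc1)c1ccccc1` — 60 nM
Compound 2 `CC(Sc1nc2nn(C3COC3)cc2c(=O)n1-c1ccccc1)c1ccccc1` — 109 nM

Of the compounds shown here, two have been measured in an assay on isolated protein for inhibition of Retinaldehyde dehydrogenase 3 (Homo sapiens); on this read-out higher numbers stand for weaker inhibition and lower numbers for stronger inhibition. Within the data shown here, compound 2 holds the higher of the two numbers, yet its only neighbour is compound 1, and the step of a 1.8-fold higher number from compound 1 to compound 2 (0.26 log units; within the scatter) is small enough to leave the two indistinguishable. Compound 3 `CC(Sc1nc2nn(C3(C)COC3)cc2c(=O)n1-c1ccccc1)c1ccccc1` is the unmeasured member of the set. It differs from compound 2 by methyl in place of hydrogen on a saturated ring carbon. Among the measured compounds shown here, the single measured step concerns the same ring, but it swapped the whole oxetane-bearing group and left the number within the scatter; no measured pair speaks to a methyl added on the ring itself. With nothing else to go on, the expectation for this assay is a step of about a 1.0-fold higher number from compound 2 to compound 3 (0.00 log units; within the scatter), in no direction beyond the scatter. Compound 3 is therefore estimated at 110 nM, expected to lie between 50 nM and 250 nM.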

Compound 3, half-maximal inhibitory concentration in the Retinaldehyde dehydrogenase 3 assay: 50 nM
Compound 3: middle estimate off by 2.2-fold (0.34 log units), on the high side; the range from low to high includes it.
By their numbers in the Retinaldehyde dehydrogenase 3 assay, from the lowest: compounds 3, 1 and 2 (each within the scatter of the next, the first and the last beyond it).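

Among these compounds, in the Retinaldehyde dehydrogenase 3 assay compound 2 gives 109 nM and compound 3 gives 50 nM, and the methyl on the saturated ring carbon gives the first step in this set that lies beyond the scatter, a 2.2-fold lower number from compound 2 to compound 3 (0.34 log units; beyond the scatter), so this carbon of the oxetane ring responds to the added methyl. Measured against the group on the aromatic nitrogen of compound 1, the Retinaldehyde dehydrogenase 3 assay shows a 1.2-fold lower number from compound 1 to compound 3 (0.08 log units; within the scatter), which leaves 3-methyloxetan-3-yl and (oxetan-3-yl)methyl indistinguishable. In a physicochemical assay for solubility, using the shake flask method, in phosphate buffer, with a stated time of 24 h, at pH 7.4 (a higher number here means a more soluble compound, a lower number a less soluble compound), compound 2 gives 26000 nM and compound 3 gives 19000 nM; the same methyl gives a 1.4-fold lower number from compound 2 to compound 3 (0.14 log units; within the scatter), so compound 2 and compound 3 do not separate on solubility.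

No data shown here account for the step in inhibition. As far as these compounds go, whether an ethyl group, a fluorine atom or an amine on the same ring carbon would carry the number further, or reverse it, remains open.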